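Anilino substituent change toward compound 4

The source may hold more compounds than are shown below. What is called first, only, known or untested is meant among the compounds shown, and "the series" means these compounds.

Compound 3 `COc1cc(-c2nn(-c3ccccc3)cc2C(=O)/C=C\Nc2ccc(C(F)(F)F)cc2)cc(OC)c1OC` stands at the edge of the series in an ADME assay on HaCaT cells (Homo sapiens) for antiproliferative activity, read by MTT assay, with a stated time of 48 h; a lower number here means a stronger inhibitor, a higher number a weaker inhibitor: compound 3 gives > 50000 nM, and this is the limit of > 50000 nM in this assay, at which 1 of the 3 values shown sits, rather than a number. In this assay compound 1 `COc1cc(-c2nn(-c3ccccc3)cc2C(=O)/C=C\Nc2ccc(F)cc2)cc(OC)c1OC` gives 25700 nM and compound 2 `COc1cc(-c2nn(-c3ccccc3)cc2C(=O)/C=C\Nc2ccc(Cl)cc2)cc(OC)c1OC` gives 30200 nM. The measured steps are a 1.2-fold higher number from compound 1 to compound 2 (0.07 log units; within the scatter), an at least 1.9-fold higher number from compound 1 to compound 3 (0.28 log units; that floor lies within the scatter) and an at least 1.6-fold higher number from compound 2 to compound 3 (0.21 log units; that floor lies within the scatter). Compound 4 `COc1cc(-c2nn(-c3ccccc3)cc2C(=O)/C=C\Nc2ccc(O)cc2)cc(OC)c1OC` differs from compound 3 by hydroxy in place of trifluoromethyl on an aromatic carbon. Going by the values given here, no measured step introduces a hydroxy group, so these steps offer no direct guide; all three substituent swaps so far moved this assay little. The expected step is an at least 1.2-fold lower number from compound 3 to compound 4 (0.09 log units; that floor lies within the scatter), in no firm direction. The estimate for compound 4 in this assay is 40000 nM, with a range from 15000 nM to 100000 nM.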

Compound 4, half-maximal inhibitory concentration: 17600 nM
Estimate against measurement, compound 4: 2.3-fold (0.36 log units) above; measured number inside the range.
By their numbers in this assay, from the lowest: compounds 4, 1 and 2 (each within the scatter of the next). At a limit, above all of these: compound 3.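

In this assay this position gives its first step beyond the scatter: an at least 2.8-fold lower number from compound 3 to compound 4 (0.45 log units; beyond the scatter). Compound 3 holds a limit there, not a number, so the size of that step is only a floor: the limit of > 50000 nM in this assay, at which 1 of the 4 values shown sits. Hydroxy in place of chloro gives a 1.7-fold lower number from compound 2 to compound 4 (0.23 log units; within the scatter), and hydroxy in place of fluoro gives a 1.5-fold lower number from compound 1 to compound 4 (0.16 log units; within the scatter), so hydroxy separates only from trifluoromethyl. Going by these compounds, how an amine or a carboxylic acid at this place would read stays open, as does the actual number for compound 3.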